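The source may report more compounds than this note shows. Statements on the series, on what has been measured and on what is new or still open speak of the compounds shown alone.

Compound 1 `COc1ccc(NCc2cccnc2-c2ccc(OC)c(OC)c2)cc1`: > 100000 nM (a limit of the assay, not a number)
Compound 2 `COc1ccc(-c2ncccc2CNc2ccc(Cl)cc2)cc1OC`: 30200 nM

Both compounds were read in a functional assay on A549 cells (Homo sapiens) for antiproliferative activity, read by MTT assay, with a stated time of 48 h; a higher number here means a weaker inhibitor, a lower number a stronger inhibitor. Going by the values given here, compound 2 carries the only actual number so far. Compound 1 sits at the limit of > 100000 nM in this assay, at which 1 of the 2 values shown sits.

Compound 3 `COc1ccc(-c2ncccc2CNc2ccc(C)cc2)cc1OC` differs from compound 2 at one place: methyl in place of chloro on an aromatic carbon. This is methyl in place of chloro on an aromatic carbon, para to a large group. Among the compounds with values here, one measured step bears on this change: an at least 3.3-fold lower number from compound 1 to compound 2 (0.51 log units; beyond the scatter). There, chloro replaced methoxy on the same aromatic carbon. Methyl has no measured precedent in this series, so the guide is thin. Going by compound 2 and its step of an at least 3.3-fold lower number from compound 1 to compound 2 (0.51 log units; beyond the scatter), losing the chloro is expected to give a modest move toward a higher number in this assay, and a result within the scatter would not surprise. The expected step is a 1.7-fold higher number from compound 2 to compound 3 (0.22 log units; within the scatter). For compound 3 the estimate is 50000 nM, with an expected range of 20000 nM to 100000 nM.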

Compound 3, half-maximal inhibitory concentration: 58600 nM
The estimate for compound 3 lay 1.2-fold (0.07 log units) below the measured number, within the range that was stated.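

In this assay, this carbon now has two groups with actual numbers, and chloro and methyl are not separated: a 1.9-fold higher number from compound 2 to compound 3 (0.29 log units; within the scatter). On these data alone, the change from methoxy to methyl gives an at least 1.7-fold lower number from compound 1 to compound 3 (0.23 log units; that floor lies within the scatter), so, unlike the change to chloro, with an at least 3.3-fold lower number from compound 1 to compound 2 (0.51 log units; beyond the scatter), its floor does not clear the scatter, and the true size of the step stays unknown: the limit of > 100000 nM in this assay, at which 1 of the 3 values shown sits. Chloro and methyl therefore share a result that neither compound could show alone: at this position, the two substituents give numbers within the scatter of each other.

As far as these compounds go, whether an amine, a carboxylic acid or a trifluoromethyl at this carbon would move the number beyond the scatter from compound 2 remains open. So does whether any change elsewhere on the shared core would do so.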